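Second methoxy on compound 2

The source may hold more compounds than are shown below. What is called first, only, known or untested is meant among the compounds shown, and "the series" means these compounds.

In a functional assay on A549/CDDP cells (Homo sapiens) for antiproliferative activity, read by MTT assay, with a stated time of 72 h (a higher number here means a weaker inhibitor, a lower number a stronger inhibitor), compound 1 `Cc1nc(C)c(/C=C/C(=O)/C=C/c2cccc(O)c2)nc1C` gives 3700 nM and compound 2 `COc1cccc(/C=C/C(=O)/C=C/c2nc(C)c(C)nc2C)c1` gives 3440 nM, so the two stand level within the scatter. Compound 3 `COc1ccc(/C=C/C(=O)/C=C/c2nc(C)c(C)nc2C)cc1OC` differs from compound 2 by methoxy in place of hydrogen on an aromatic carbon, ortho to a methoxy group and para to a large group. Within the data shown here, the only measured step with any bearing is methyl in place of hydrogen on an oxygen, a 1.1-fold lower number from compound 1 to compound 2 (0.03 log units; within the scatter), and it is a different change. The expected step in this assay is a 1.1-fold lower number from compound 2 to compound 3 (0.06 log units; within the scatter), none beyond the scatter. For compound 3 the estimated value is 3000 nM, with an expected range of 1300 nM to 7000 nM.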

Compound 3, half-maximal inhibitory concentration: 2440 nM
Beside the measured number, compound 3's estimate is 1.2-fold (0.09 log units) above it; measured number inside the range.
By their numbers in this assay, from the lowest: compounds 3, 2 and 1 (each within the scatter of the next).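

Among these compounds, the earlier step changed only the group on the oxygen; this one is the first reading at a ring carbon, ortho to a methoxy group and para to a large group. In this assay, methoxy in place of hydrogen there gives (a 1.4-fold lower number from compound 2 to compound 3 (0.15 log units; within the scatter)), so this position accepts the added methoxy with no change beyond the scatter. No measurement at hand offers an explanation for this step. From the compounds shown here alone, whether an amine or a carboxylic acid on this carbon would move the number beyond the scatter remains open.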